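Iodo to chloro: the step to compound 4

The source may hold more compounds than are shown below. What is called first, only, known or untested is meant among the compounds shown, and "the series" means these compounds.

Measured so far in a physicochemical assay, with a stated time of 6 min; a higher number here means a weaker inhibitor, a lower number a stronger inhibitor:
- compound 1 `COc1ccc(NC(=O)Nc2nc(-c3cc4cc([N+](=O)[O-])ccc4o3)cs2)cc1` gives 121000 nM
- compound 2 `O=C(Nc1ccccc1)Nc1nc(-c2cc3cc([N+](=O)[O-])ccc3o2)cs1` gives 183000 nM
- compound 3 `O=C(Nc1ccc(I)cc1)Nc1nc(-c2cc3cc([N+](=O)[O-])ccc3o2)cs1` gives 62400 nM

Compound 3 carries the lowest of the three numbers, but only one of its two gaps clears the scatter. That gap is a 2.9-fold lower number from compound 2 to compound 3 (0.47 log units; beyond the scatter), whereas a 1.9-fold lower number from compound 1 to compound 3 (0.29 log units; within the scatter) does not separate the pair, and neither does a 1.5-fold higher number from compound 1 to compound 2 (0.18 log units; within the scatter) at the other side of the set.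

The next compound is compound 4 `O=C(Nc1ccc(Cl)cc1)Nc1nc(-c2cc3cc([N+](=O)[O-])ccc3o2)cs1`, with chloro in place of iodo on an aromatic carbon. For the measured compounds named here, no measured step exchanges one halogen for another, so the evidence is indirect. The nearest guide is the hydrogen-to-iodo change at the same place, a 2.9-fold lower number from compound 2 to compound 3 (0.47 log units; beyond the scatter), which is modest. The methoxy-to-iodo change, a 1.9-fold lower number from compound 1 to compound 3 (0.29 log units; within the scatter), adds little. The three values span a narrow range, so a large move in this assay is not expected. A small step toward a higher number is expected, probably not beyond the scatter. The estimated step is a 1.4-fold higher number from compound 3 to compound 4 (0.16 log units; within the scatter) as the expected outcome. Compound 4 is estimated at 90000 nM, with 40000 nM to 170000 nM as the expected range.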

Compound 4, half-maximal inhibitory concentration: 117000 nM
For compound 4 the middle estimate is 1.3-fold (0.11 log units) below the measured one, within the range that was stated.
By their numbers in this assay, from the lowest: compounds 3, 4, 1 and 2 (each within the scatter of the next, the first and the last beyond it).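

For the compounds shown here, the step of a 1.9-fold higher number from compound 3 to compound 4 (0.27 log units; within the scatter) is the one direct exchange of one halogen for another at the aromatic carbon para to a large group, and in this assay it does not separate 4-iodophenyl from 4-chlorophenyl. Measured against hydrogen at this place the two halogens do not read alike: the step of a 2.9-fold lower number from compound 2 to compound 3 (0.47 log units; beyond the scatter) lies beyond the scatter while the step of a 1.6-fold lower number from compound 2 to compound 4 (0.19 log units; within the scatter) does not, so the only separation at this position rests on iodo and chloro does not repeat it. Chloro and methoxy are not separated either, the step being a 1.0-fold lower number from compound 1 to compound 4 (0.01 log units; within the scatter) here, and no measurement to hand accounts for any of these steps.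

The compounds shown cover only hydrogen, methoxy, chloro and iodo at this one place, so it stays open whether fluoro, a dimethylamino group or a carboxylic acid there would leave the narrow band of these numbers. Also open, going by these compounds, is whether the iodo and hydrogen pair is more than an end-to-end gap in this band, as compound 3 stands within the scatter of both compound 1 and compound 4.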